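This account rests on a few compounds, and the source may have more. Where it says the series, first, only, none or still open, it means among the compounds named here.

Compound 1 `CCc1cc(C(C)=O)c(O)cc1OCCCCCC(C)(C)c1nnn(C)n1` and compound 2 `CCc1cc(C(C)=O)c(O)cc1OCCCCCC[S+](C)[O-]` share a core and a six-carbon chain on the aromatic oxygen, and differ only in the group at the end of that chain. In an assay on isolated protein for inhibition of leukotriene B4 receptor 1 (Homo sapiens), tested at 10 uM (a higher number here means more inhibition at the concentration tested (going by the name of the read-out), a lower number less inhibition), compound 1 gives 95%, and compound 2 gives 92%. The step of a number 3 percentage points lower from compound 1 to compound 2 (within the scatter) shows that swapping the terminal group leaves the read-out essentially where it was. Compound 2 thus stands with compound 1 within the usual scatter, at a high level of inhibition.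

Compound 3 `CCc1cc(C(C)=O)c(O)cc1OCCCCCCS(C)(=O)=O` is the next step from compound 2: a group of 4 heavy atoms (1 carbon, 2 oxygen, 1 sulfur; no ring) in place of a group of 3 heavy atoms (1 carbon, 1 oxygen, 1 sulfur; no ring), on a saturated chain carbon, six bonds along the chain from an oxygen on an aromatic ring. Among the compounds with values here, the only measured step that bears on this change is a number 3 percentage points lower from compound 1 to compound 2 (within the scatter), a small one, so the terminal group on this chain has so far had no visible weight. The step from compound 2 to compound 3 is therefore expected to lie within the scatter, a number 2 percentage points lower from compound 2 to compound 3 (within the scatter), in no clear direction. Compound 3 is expected at 90%, within the range 72% to 98%.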

Compound 3, a percentage reported as inhibition, at one concentration (the size of the read-out at that concentration, not a potency): 99%
Estimate against measurement, compound 3: 9 percentage points below; measured number outside the range, above it.
By their numbers in this assay, from the lowest: compounds 2, 1 and 3 (each within the scatter of the next).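

With methylsulfonyl on the saturated chain carbon, this assay gives a number 7 percentage points higher from compound 2 to compound 3 (within the scatter), and (methylsulfonyl)methyl in place of 1-methyl-1-(2-methyl-2H-tetrazol-5-yl)ethyl gives a number 4 percentage points higher from compound 1 to compound 3 (within the scatter). The three end groups, one of them with a ring and two without, therefore cannot be told apart at this position, and no change at the end of the chain has yet moved the read-out beyond the scatter. Nothing measured here accounts for the small differences among them.

Going by these compounds, it remains open whether a carboxylic acid or an amine at the end of the chain, or a longer chain, would move the number clearly away from these values. On these data alone, it is also open whether the three compounds would separate in a measure of potency, as this read-out comes from one concentration only.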